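A phenyl group on the core of compound 1

The compounds below may be only part of what the source reports. "The series", "measured", "known", "first", "only" and "open" are said of these compounds alone.

In a functional assay on NCI-H460 cells (Homo sapiens) for inhibition (on this read-out lower numbers stand for stronger inhibition of growth and higher numbers for weaker inhibition of growth), compound 1 (`CCOC(=O)C1=C(N)Oc2ccccc2C1C(C#N)C(=O)OCC`) gives 157000 nM. For the measured compounds named here, that places it at the high end of the three numbers so far, level within the scatter with compound 3 (`CCOC(=O)C1=C(N)Oc2ccc(C)cc2C1C(C#N)C(=O)OCC`), which gives 102000 nM. Compound 2 (`CCOC(=O)C1=C(N)Oc2ccc(-c3ccc(C(C)(C)C)cc3)cc2C1C(C#N)C(=O)OCC`) stands far lower, at 160 nM.

The unmeasured compound 4 (`CCOC(=O)C1=C(N)Oc2ccc(-c3ccccc3)cc2C1C(C#N)C(=O)OCC`) differs from compound 1 by phenyl in place of hydrogen on an aromatic carbon. Two measured changes at that same carbon bear on it. Methyl gave a 1.5-fold lower number from compound 1 to compound 3 (0.19 log units; within the scatter), which is within the scatter, while 4-(tert-butyl)phenyl gave a 980-fold lower number from compound 1 to compound 2 (2.99 log units; beyond the scatter), a large step. Phenyl shares the ring of that larger group but lacks its tert-butyl, and the data do not show how the large step divides between the two parts. A clear drop is therefore likely, though probably not the full one.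

The expected change is a 52-fold lower number from compound 1 to compound 4 (1.72 log units; beyond the scatter), a lower number beyond the scatter. Compound 4 is estimated to give about 3000 nM, within an expected range of 500 nM to 20000 nM.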

Compound 4, concentration for 50% growth inhibition: 15900 nM
For compound 4 the middle estimate is 5.3-fold (0.72 log units) below the measured one, within the range that was stated.
By their numbers in this assay, from the lowest: compound 2; then compound 4; then compounds 3 and 1 (each within the scatter of the next).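

In this assay, phenyl alone already gives a 9.9-fold lower number from compound 1 to compound 4 (0.99 log units; beyond the scatter) as a modest step, and replacing methyl with phenyl gives a 6.4-fold lower number from compound 3 to compound 4 (0.81 log units; beyond the scatter) as another modest step, so a bare aromatic ring at this carbon moves the number where methyl did not. The tert-butyl on that ring matters even more, since its removal gives a 99-fold higher number from compound 2 to compound 4 (2.00 log units; beyond the scatter) as a large step, showing that much of the strength of compound 2 depends on this one group and not on the ring alone. Nothing measured here explains why either group has this effect.

Still open, from the compounds shown here alone, is whether an ethyl group, an amine or a carboxylic acid in place of the tert-butyl would keep the number low. The compounds shown also leave open whether 4-(tert-butyl)phenyl would act the same way on another aromatic carbon of the shared core.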